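Side chain replacement on the shared core: estimate for compound 4

The source may report more compounds than this note shows. Statements on the series, on what has been measured and on what is new or still open speak of the compounds shown alone.

Measured so far:
compound 1, `COc1ccc(-c2nc(N=C(N)N)sc2-c2ccc(OC)cc2)cc1` — 2 uM
compound 2, `COc1ccc(-c2nc(CNC(C)=O)sc2-c2ccc(OC)cc2)cc1` — 8.1 uM
compound 3, `COc1ccc(-c2nc(CNC(=O)NC(C)C)sc2-c2ccc(OC)cc2)cc1` — 5.7 uM

In a functional assay (aorta) with Rattus norvegicus as the target (on this read-out lower numbers stand for an effect already at smaller amounts and higher numbers for an effect only at larger amounts of compound), compound 3 stands second highest of the three numbers. Its nearest neighbour is compound 2, a 1.4-fold lower number from compound 2 to compound 3 (0.15 log units; within the scatter); its furthest is compound 1, a 2.9-fold higher number from compound 1 to compound 3 (0.45 log units; beyond the scatter).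

Compound 4, `COc1ccc(-c2nc(/C=C/C(=O)O)sc2-c2ccc(OC)cc2)cc1`, differs from compound 3 in one place: 2-carboxyethenyl in place of ((isopropylcarbamoyl)amino)methyl on an aromatic carbon.

For the measured compounds named here, two measured steps bear on this position. Both exchanges of the group on this aromatic carbon gave modest rises, a 4.1-fold higher number from compound 1 to compound 2 (0.61 log units; beyond the scatter) and a 2.9-fold higher number from compound 1 to compound 3 (0.45 log units; beyond the scatter), while the exchange between the two chains, a 1.4-fold lower number from compound 2 to compound 3 (0.15 log units; within the scatter), stayed within the scatter. Going by the values given here, no measured step trades such a chain for 2-carboxyethenyl. A modest step is therefore expected, a 1.4-fold higher number from compound 3 to compound 4 (0.15 log units; within the scatter), with direction uncertain. For compound 4 the estimate is 8 uM, range 3 uM to 25 uM.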

Compound 4, concentration for half-maximal effect: 55 uM
Compound 4: the middle estimate sits 6.9-fold (0.84 log units) below what was measured, outside the stated range (above it).
By their numbers in this assay, from the lowest: compound 1; then compounds 3 and 2 (each within the scatter of the next); then compound 4.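

In this assay, for the compounds shown here, 2-carboxyethenyl on this aromatic carbon is the first group to move the number clearly away from both chains, with a 9.6-fold higher number from compound 3 to compound 4 (0.98 log units; beyond the scatter) and a 6.8-fold higher number from compound 2 to compound 4 (0.83 log units; beyond the scatter), although the two chains themselves lie within the scatter of each other. The step from the group of the first compound is the largest shown, a 28-fold higher number from compound 1 to compound 4 (1.44 log units; beyond the scatter), so the position spans a wider range than the earlier compounds showed. Nothing available explains this shift.

Going by these compounds, whether the rise follows the carboxylic acid or the ethenyl link stays open. A 2-carboxyethyl group, a methyl ester or a primary amide at this position would separate the two.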